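Bromo-to-methyl swap on the aryl ring of compound 2

The source may report more compounds than this note shows. Statements on the series, on what has been measured and on what is new or still open speak of the compounds shown alone.

Measured so far:
Compound 1 `CCCC1=C(C(=O)OCC)C(c2ccccc2)C=C(c2ccccc2)N1` — in an assay on SH-SY5Y cells for inhibition of Voltage-dependent L-type calcium channel subunit alpha-1D (Homo sapiens), read by calcium flux, with a stated time of 15 min (a lower number here means a stronger inhibitor, a higher number a weaker inhibitor), compound 1 gives 9900 nM.
Compound 2 `CC1=C(C(=O)SC(C)(C)C)C(c2ccc(Br)cc2)C=C(c2ccc(C)cc2)N1` — in this assay compound 2 gives 59600 nM.

Compound 2 stands at the highest of the two numbers; its nearest neighbour is compound 1, whose number is lower by a margin beyond the usual scatter. Among the compounds with values here, the two compounds differ in several places at once, so no single-point step between them can be read.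

Compound 3 `CC1=C(C(=O)SC(C)(C)C)C(c2ccc(C)cc2)C=C(c2ccc(C)cc2)N1` is the next member. It differs from compound 2 by methyl in place of bromo on an aromatic carbon, which read one bond further out is 4-bromophenyl to 4-methylphenyl. Within the data shown here, no measured pair shows this change, so its size is unknown from these data. The expected step of a 1.2-fold higher number from compound 2 to compound 3 (0.07 log units; within the scatter) is none beyond the scatter. Compound 3 is therefore estimated at 70000 nM, with a range from 25000 nM to 200000 nM.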

Compound 3, half-maximal inhibitory concentration: > 100000 nM
Compound 3: only a limit was reported (the forecaster's own chance of this, stated with the estimate: 25%); at least 1.4-fold (0.15 log units) between middle value and limit.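

In this assay compound 3 gives > 100000 nM, which is a limit of the assay and not a number. Within the data shown here, this is the first reading of methyl in place of bromo on an aromatic carbon, para to a large group, and it gives an at least 1.6-fold higher number from compound 2 to compound 3 (0.22 log units; that floor lies within the scatter), so the pair is not separated by what can be read. The change therefore has a floor but no upper size, and the value behind that floor is a limit: the limit of > 100000 nM in this assay, at which 1 of the 3 values shown sits.

From the compounds shown here alone, whether an amine, a methoxy group or a carboxylic acid in this place would bring the number down in this assay remains open. Also open, going by these compounds, is how much of the gap from compound 1 belongs to each of the several places in which it differs from compound 2.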